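Chloro for fluoro on a second hydrazide core

The compounds below may be only part of what the source reports. "The series", "measured", "known", "first", "only" and "open" are said of these compounds alone.

Measured compounds:
compound 1 `CC(=N)Nc1cccc(C(=O)NNC(=O)CC(CC(=O)O)c2ccc(F)cc2)c1` gives 1.6
compound 2 `CC(=N)Nc1cccc(C(=O)NNC(=O)CC(CC(=O)O)c2ccc(Cl)cc2)c1` gives 2
compound 3 `N=C(N)Nc1cccc(C(=O)NNC(=O)NC(CC(=O)O)c2ccc(F)cc2)c1` gives 0.86

In a physicochemical assay for lipophilicity (on this read-out lower numbers stand for lower lipophilicity and higher numbers for higher lipophilicity), the step from compound 1 to compound 2 is a number 0.40 log units higher from compound 1 to compound 2 (beyond the scatter); the change is chloro in place of fluoro on an aromatic carbon. Compound 3 carries a different core, and the difference between the two cores is not broken down here. Compound 4 `N=C(N)Nc1cccc(C(=O)NNC(=O)NC(CC(=O)O)c2ccc(Cl)cc2)c1` is not yet measured in this assay; it differs from compound 3 by chloro in place of fluoro on an aromatic carbon, the same change as from compound 1 to compound 2, made on the other core. Resting on the step from compound 1 to compound 2 a number 0.40 log units higher from compound 1 to compound 2 (beyond the scatter), the expected step from compound 3 to compound 4 is a number 0.40 log units higher from compound 3 to compound 4 (beyond the scatter). Compound 4 is therefore estimated at 1.26 in this assay, with the range 0.9 to 1.6.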

Compound 4, partition coefficient: 1.26
For compound 4 middle estimate and measured number coincide at the digits printed, and the stated range covers the measured number.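

In this assay the change from 4-fluorophenyl to 4-chlorophenyl gives a number 0.40 log units higher from compound 3 to compound 4 (beyond the scatter) and, on the core of compound 1, a number 0.40 log units higher from compound 1 to compound 2 (beyond the scatter); the step therefore carried over from one core to the other at the digits printed. This rests on a single pair on each of two cores, so it shows agreement between these four compounds and no general rule for the series. Nothing in the data shown bears on why the two steps agree.

The compounds shown carry only fluoro and chloro at this place, so the step to bromo, methoxy or nitrile on either core stays open. From the compounds shown here alone, whether the step would hold on a third core, or with a methyl ester in place of the carboxylic acid, also stays open.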